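This account rests on a few compounds, and the source may have more. Where it says the series, first, only, none or still open, it means among the compounds named here.

In a functional assay on G-361 cells (Homo sapiens) for antiproliferative activity, with a stated time of 72 h (a higher number here means a weaker inhibitor, a lower number a stronger inhibitor), compound 1 (`OC[C@H]1O[C@@H](n2cnc3c(NCc4cccc(Br)c4)ncnc32)[C@H](O)[C@@H]1O`) reads > 166000 nM, which is a limit and not a number. For the measured compounds named here, compound 2 (`OC[C@H]1O[C@@H](n2cnc3c(NCc4ccc(Cl)cc4Cl)ncnc32)[C@H](O)[C@@H]1O`) gives 128000 nM, the only true number so far. Compound 3 (`OC[C@H]1O[C@@H](n2cnc3c(NCc4ccc(Cl)c(Cl)c4)ncnc32)[C@H](O)[C@@H]1O`) differs from it by 3,4-dichlorophenyl in place of 2,4-dichlorophenyl on a saturated chain carbon bound to a nitrogen on an aromatic ring, with 3,4-dichlorophenyl in place of 2,4-dichlorophenyl on a saturated chain carbon bound to a nitrogen on an aromatic ring. Going by the values given here, the one measured step at this place, an at least 1.2-fold lower number from compound 1 to compound 2 (0.11 log units; that floor lies within the scatter), has a floor within the scatter, so no step beyond the scatter is expected in this assay. Compound 3 is expected at 100000 nM, with an estimated range of 35000 nM to 170000 nM. The expected change is a 1.3-fold lower number from compound 2 to compound 3 (0.11 log units; within the scatter).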

Compound 3, half-maximal inhibitory concentration: 145000 nM
Estimate against measurement, compound 3: 1.5-fold (0.16 log units) below; measured number inside the range.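

Replacing 2,4-dichlorophenyl with 3,4-dichlorophenyl on a saturated chain carbon bound to a nitrogen on an aromatic ring gives a 1.1-fold higher number from compound 2 to compound 3 (0.05 log units; within the scatter), so in this assay this change of the same atoms, joined differently, is not resolved from no change. Replacing 3-bromophenyl with 3,4-dichlorophenyl at this place gives an at least 1.1-fold lower number from compound 1 to compound 3 (0.05 log units; that floor lies within the scatter), which also shows no step beyond the scatter. Compound 1 remains a limit and not a number: the limit of > 166000 nM in this assay, at which 1 of the 3 values shown sits.

On these data alone, it remains open whether a ring without halogen, such as plain phenyl or methoxyphenyl, would read differently at this place in this assay. The same holds for a carboxylic acid on the ring or a longer chain to it.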